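The source may hold more compounds than are shown below. What is called first, only, known or untested is meant among the compounds shown, and "the series" means these compounds.

Of the compounds shown here, three of a shared core have been measured in a physicochemical assay for lipophilicity, read by HPLC, at pH 7.5; on this read-out higher numbers stand for higher lipophilicity and lower numbers for lower lipophilicity. Compound 1, `CCOc1ccccc1-c1ccc(-c2nc(NC(C)C(=O)O)c3ccncc3n2)cc1`, gives 2.1. Compound 2, `CC[C@@H](Nc1c(C#N)c(-c2ccc(-c3ccccc3OC)cc2)nc2cnccc12)C(N)=O`, gives 2.7. Compound 3, `CCOc1ccccc1-c1ccc(-c2nc3cnccc3c(N)c2C#N)cc1`, gives 3. Among these three numbers compound 2 stands second highest: the nearest to it is compound 3, whose number is higher by an amount that lies within the usual scatter of repeated measurements, so no order can be read between those two; the furthest is compound 1, whose number is lower by an amount beyond the scatter. No pair of these compounds differs in only one place, so no single step can be isolated from the measured set.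

Compound 4, `CC[C@@H](Nc1c(C#N)c(-c2ccc(-c3ccccc3F)cc2)nc2cnccc12)C(N)=O`, has not yet been measured in this assay. It differs from compound 2 in one place: fluoro in place of methoxy on an aromatic carbon. Going by the values given here, with no measured pair sharing this change, the expectation rests on the size of the change alone, and a small step is expected, not beyond the scatter, if anything upward. The step from compound 2 to compound 4 is estimated at a number 0.10 log units higher from compound 2 to compound 4 (within the scatter). Compound 4 is therefore expected to give about 2.8 in this assay, in a range from 2.4 to 3.2.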

Compound 4, distribution coefficient: 2.7
Beside the measured number, compound 4's estimate is 0.10 log units above it; the measured number falls inside the stated range.
By their numbers in this assay, from the lowest: compound 1; then compounds 2, 4 and 3 (each within the scatter of the next).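

In this assay, going by these compounds alone, fluoro in place of methoxy on an aromatic carbon ortho to a large group gives no change at the digits printed from compound 2 to compound 4 (within the scatter), and this is the only step in the set that isolates a change in one place. It shows that, with the rest of the structure held fixed, this read-out does not separate 2-methoxyphenyl from 2-fluorophenyl, even though the exchange removes a carbon, an oxygen and a hydrogen-bond acceptor and brings in a single fluorine. Nothing on hand explains why the exchange leaves the number where it stands.

On these data alone, this single pair tests only two substituents at one place, so it remains open whether an amine, a hydroxyl or a propoxy chain on the same aromatic carbon would also stay within the scatter of compound 2. As far as these compounds go, it is also open whether fluoro in place of methoxy would read the same way on a compound carrying something other than the amino amide side chain of compound 2, such as the plain amine of compound 3.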